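Swapping methoxy for chloro on a diarylidene piperazinedione

This account rests on a few compounds, and the source may have more. Where it says the series, first, only, none or still open, it means among the compounds named here.

Measured compounds:
compound 1 `COc1ccccc1/C=c1/[nH]c(=O)/c(=C\c2ccccc2OC)[nH]c1=O`: "not active" (no number reported)
compound 2 `C=CCn1c(=O)/c(=C\c2ccc(F)c(Br)c2)[nH]c(=O)/c1=C\c1ccccc1OC`: "not active" (no number reported)
compound 3 `C=CCn1c(=O)/c(=C\c2ccccc2OC)[nH]c(=O)/c1=C\c1ccccc1OC`: 13400 nM

Among the measured compounds shown here, in a functional assay on BGC-823 cells (Homo sapiens) for cytotoxicity, read by CCK-8 assay, with a stated time of 72 h (on this read-out lower numbers stand for stronger inhibition and higher numbers for weaker inhibition), compound 3 gives 13400 nM, the only number in this set. Compound 1 is reported as "not active" (no number reported) in this assay, and compound 2 as "not active" (no number reported); neither carries a number, so nothing can be said about their size relative to compound 3. Compound 4 `C=CCn1c(=O)/c(=C\c2ccccc2Cl)[nH]c(=O)/c1=C\c1ccccc1OC` differs from compound 3 by chloro in place of methoxy on an aromatic carbon. For the measured compounds named here, no step between two measured compounds is available, so the effect of this change is unknown. The expected step is a 1.1-fold lower number from compound 3 to compound 4 (0.05 log units; within the scatter), a step that is expected to stay within the usual scatter. Compound 4 is therefore estimated at 12000 nM, with a range from 4000 nM to 40000 nM.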

Compound 4, half-maximal inhibitory concentration: 4600 nM
Compound 4: middle estimate off by 2.6-fold (0.42 log units), on the high side; low and high end bracket the measured number.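

In this assay the swap of 2-methoxyphenyl to 2-chlorophenyl gives a 2.9-fold lower number from compound 3 to compound 4 (0.46 log units; beyond the scatter) and so shows that the read-out responds to the group at this place on the aromatic ring. The earlier compounds shown here could not show this, as compound 3 alone carried a number among them. Nothing measured here accounts for the lower number of compound 4. The compounds shown leave open how an amine or a carboxylic acid at this place would read, and whether the same swap on the remaining 2-methoxyphenyl of compound 4 would also lower the number.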